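Compound 2 to compound 4: a dimethoxyphenyl swap

The compounds below may be only part of what the source reports. "The series", "measured", "known", "first", "only" and "open" are said of these compounds alone.

In a functional assay on CCRF-CEM cells (Homo sapiens) for antiproliferative activity, with a stated time of 72 h (a higher number here means a weaker inhibitor, a lower number a stronger inhibitor), compound 2 (`Cc1cccc(CNc2ncnc3c2ncn3[C@@H]2O[C@H](CO)[C@@H](O)[C@H]2O)c1`) gives 19100 nM and compound 1 (`OC[C@H]1O[C@@H](n2cnc3c(NCc4ccccc4Cl)ncnc32)[C@H](O)[C@@H]1O`) gives 14500 nM, which places both at the high end of the series, while compound 3 (`OC[C@H]1O[C@@H](n2cnc3c(NCc4ccc(Cl)c(Cl)c4)ncnc32)[C@H](O)[C@@H]1O`) gives a lower number (3800 nM). Compound 4 (`COc1cc(CNc2ncnc3c2ncn3[C@@H]2O[C@H](CO)[C@@H](O)[C@H]2O)cc(OC)c1`) has 3,5-dimethoxyphenyl in place of 3-methylphenyl on a saturated chain carbon bound to a nitrogen on an aromatic ring. The measured steps change this same group: a 1.3-fold higher number from compound 1 to compound 2 (0.12 log units; within the scatter) stays within the scatter, whereas a 5.0-fold lower number from compound 2 to compound 3 (0.70 log units; beyond the scatter) and a 3.8-fold lower number from compound 1 to compound 3 (0.58 log units; beyond the scatter) are modest and both lead to 3,4-dichlorophenyl. Among the measured compounds shown here, no measured compound carries methoxy groups, so only a small drop, not beyond the scatter, is expected (a 1.5-fold lower number from compound 2 to compound 4 (0.17 log units; within the scatter)). For compound 4 the estimate is 13000 nM (range 4500 nM to 35000 nM).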

Compound 4, half-maximal inhibitory concentration: > 166000 nM
Compound 4: a limit, no number; the forecaster's own chance of this, stated with the estimate: 10%; middle value at least 12-fold (1.10 log units) away from the limit.
By their numbers in this assay, from the lowest: compound 3; then compounds 1 and 2 (each within the scatter of the next). At a limit, above all of these: compound 4.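

In this assay compound 4 gives a limit, not a number: the limit of > 166000 nM in this assay, at which 1 of the 4 values shown sits. The change to 3,5-dimethoxyphenyl at this place brings an at least 8.6-fold higher number from compound 2 to compound 4 (0.93 log units; beyond the scatter), an at least 11-fold higher number from compound 1 to compound 4 (1.05 log units; beyond the scatter) and an at least 43-fold higher number from compound 3 to compound 4 (1.64 log units; beyond the scatter). Among the compounds shown here, the earlier steps beyond the scatter all led to lower numbers, so this is the first change here that gives a higher one.

As far as these compounds go, the true size of these steps stays open. So does whether one methoxy group alone would do the same, or a hydroxy group or an amine on the phenyl ring.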